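The source may report more compounds than this note shows. Statements on the series, on what has been measured and on what is new or still open speak of the compounds shown alone.

Measured so far in a functional assay on CCRF-CEM cells (Homo sapiens) for antiproliferative activity, read by MTT assay, with a stated time of 72 h; a higher number here means a weaker inhibitor, a lower number a stronger inhibitor:
- compound 1 `NC(=O)NC(=O)/C=C/c1cccc(NC(=O)CBr)c1`: 1380 nM
- compound 2 `CNC(=O)NC(=O)c1cccc(NC(=O)C(C)Br)c1`: 9320 nM
- compound 3 `CNC(=O)NC(=O)c1cccc(NC(=O)C(C)Cl)c1`: > 20000 nM

The value of compound 3 in this assay is a limit of the assay, not a number, the one described in the limit of > 20000 nM in this assay, at which 1 of the 3 values shown sits. Going by the values given here, of the three compounds it is the only one for which no number is known, so its standing can be told only relative to compound 2.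

The next compound is compound 4 `CNC(=O)NC(=O)c1cccc(NC(=O)CBr)c1`. The change from compound 3 is bromomethyl in place of 1-chloroethyl on a carbonyl carbon. Two things happen at once: the chlorine gives way to bromine and the methyl on that chain carbon is gone. Only the halogen part has a measured counterpart: an at least 2.1-fold higher number from compound 2 to compound 3 (0.33 log units; beyond the scatter), which reads chloro in place of bromo and raised the number. Reversed, bromo in place of chloro should lower it by a comparable amount. Among the compounds with values here, the loss of the methyl has no measured step on this core; compound 2 with 1-bromoethyl gives 9320 nM, and compound 1, carrying bromomethyl on a different linker, gives 1380 nM, with no step counted between them.

Compound 4 is therefore expected to come back from the limit into measurable range, with an at least 6.6-fold lower number from compound 3 to compound 4 (0.82 log units; beyond the scatter) as the expected step. The estimate for compound 4 in this assay is 3000 nM, within 900 nM to 10000 nM.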

Compound 4, half-maximal inhibitory concentration: 3160 nM
Compound 4: the middle estimate sits 1.1-fold (0.02 log units) below what was measured, within the range that was stated.
By their numbers in this assay, from the lowest: compound 1; then compound 4; then compound 2. At a limit, above all of these: compound 3.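

In this assay the loss of the methyl now has a measured size of its own on the shared core, with bromine kept in both compounds (a 2.9-fold lower number from compound 2 to compound 4 (0.47 log units; beyond the scatter)). The change from 1-chloroethyl to bromomethyl on a carbonyl carbon (an at least 6.3-fold lower number from compound 3 to compound 4 (0.80 log units; beyond the scatter)) holds both the halogen change and the methyl loss, and each of these, read singly from compound 2, goes with a change in the same sense: chloro in place of bromo and methyl kept give the higher number. Compound 3 is held at a limit, so that step has no upper end: the limit of > 20000 nM in this assay, at which 1 of the 4 values shown sits.

Going by these compounds, how much of that step belongs to each change stays open, and chloromethyl on the same carbonyl carbon would separate the two. Also open, on these data alone, is how iodomethyl or a longer chain carrying bromine would stand on the shared core.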